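Fluoro Replacing Hydroxy: Expected Antiproliferative Outcome

This account rests on a few compounds, and the source may have more. Where it says the series, first, only, none or still open, it means among the compounds named here.

Compound 1, `Cc1c(C=C(CO)CO)n(C)c(=O)[nH]c1=O`: in an ADME assay on WI-38 cells (Homo sapiens) for antiproliferative activity, read by MTT assay, with a stated time of 72 h (a higher number here means a weaker inhibitor, a lower number a stronger inhibitor), compound 1 gives > 100000 nM, which is a limit of the assay.
Compound 2, `COc1nc(CC(O)(CO)CO)c(C)c(OC)n1`: in this assay compound 2 gives > 100000 nM, again a limit.
Compound 3, `COc1nc(CC(O)(COC(C)=O)COC(C)=O)c(C)c(OC)n1`: in this assay compound 3 gives > 100000 nM, also a limit.

Among the compounds with values here, compound 3 thus sits at the limit of > 100000 nM in this assay, at which 3 of the 3 values shown sit, and no step between two measured compounds exists to lean on. Compound 4, `COc1nc(CC(F)(COC(C)=O)COC(C)=O)c(C)c(OC)n1`, differs from compound 3 by fluoro in place of hydroxy on a saturated chain carbon bound to three saturated chain carbons. With nothing measured to point the other way, the step expected from compound 3 to compound 4 is none beyond the scatter, a number no higher from compound 3 to compound 4 (the limit leaves the size open). Compound 4 is therefore estimated at 100000 nM, within 30000 nM to 300000 nM, and most probably reported only as a limit once more.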

Compound 4, half-maximal inhibitory concentration: > 100000 nM
Compound 4 was reported as a limit (the forecaster's own chance of this, stated with the estimate: 85%); the middle value sits exactly at the limit.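

Compound 3 and compound 4 both stand only as limits in this assay, so no step can be read between them. The compounds shown leave open what fluoro in place of hydroxy changes, as every value shown is a limit: the limit of > 100000 nM in this assay, at which 4 of the 4 values shown sit.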